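Aryl swap on the amide: compound 3 to compound 4

The compounds below may be only part of what the source reports. "The series", "measured", "known", "first", "only" and "open" are said of these compounds alone.

Measured in a functional assay on A549 cells (Homo sapiens) for inhibition, read by CCK-8 assay, with a stated time of 72 h, tested at 1 uM; a higher number here means more inhibition of growth at the concentration tested, a lower number less inhibition of growth:
compound 1 `CN(C)C(=O)c1cc2cnc(Nc3ccc(NC(=O)C4(C(=O)Nc5ccc(F)cc5)CC4)cc3)nc2n1C1CCCC1`: 86.6%
compound 2 `Cc1cccc(NC(=O)C2(C(=O)Nc3ccc(Nc4ncc5cc(C(=O)N(C)C)n(C6CCCC6)c5n4)cc3)CC2)c1`: 35.2%
compound 3 `CN(C)C(=O)c1cc2cnc(Nc3ccc(NC(=O)C4(C(=O)Nc5cccc(F)c5)CC4)cc3)nc2n1C1CCCC1`: 33.2%

Compound 3 and compound 2 stand level, with a number 2 percentage points lower from compound 2 to compound 3 (within the scatter). Both sit well under compound 1.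

Still unmeasured, compound 4 `CN(C)C(=O)c1cc2cnc(Nc3ccc(NC(=O)C4(C(=O)Nc5ccc(Br)cc5)CC4)cc3)nc2n1C1CCCC1` differs from compound 3 as follows: 4-bromophenyl in place of 3-fluorophenyl on an amide-type nitrogen. In short, 4-bromophenyl replaces 3-fluorophenyl on an amide-type nitrogen.

Among the measured compounds shown here, two measured steps bear on this. Placing 3-fluorophenyl where 4-fluorophenyl stood gave a number 53.4 percentage points lower from compound 1 to compound 3 (beyond the scatter), and placing 3-methylphenyl there gave a number 51.4 percentage points lower from compound 1 to compound 2 (beyond the scatter). The fluoro-for-methyl swap on the aromatic carbon stayed within the scatter, as the comparison of compound 2 and compound 3 shows. In these three compounds, then, the two 3-substituted phenyl groups go together and the 4-fluorophenyl of compound 1 stands apart.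

For the measured compounds named here, the 4-bromophenyl of compound 4 carries the same number in its name as the group in compound 1, but no measured step covers bromo in place of fluoro. A large upward step is therefore expected, recovering much but probably not all of the drop seen from compound 1, and the uncertainty is wide.

The expected step is a number 31.8 percentage points higher from compound 3 to compound 4 (beyond the scatter).

For compound 4 the estimated value is 65%, with an expected range of 38% to 88%.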

Compound 4, percent growth inhibition at one concentration: -6.6%
Estimate against measurement, compound 4: 71.6 percentage points above; measured number below the stated range.
By their numbers in this assay, from the lowest: compound 4; then compounds 3 and 2 (each within the scatter of the next); then compound 1.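

In this assay this position on the amide-type nitrogen does not tolerate a change of halogen on the 4-substituted phenyl: bromo in place of fluoro gives a number 93.2 percentage points lower from compound 1 to compound 4 (beyond the scatter) and leaves compound 4 at -6.6% with no growth inhibition to speak of. The earlier split between 4-fluorophenyl and the two 3-substituted groups therefore does not extend to 4-substituted groups in general, since 4-bromophenyl also falls clearly under 3-fluorophenyl, with a number 39.8 percentage points lower from compound 3 to compound 4 (beyond the scatter), and under 3-methylphenyl, with a number 41.8 percentage points lower from compound 2 to compound 4 (beyond the scatter), so the substituent itself matters here and not just the number in the group's name. Nothing measured here accounts for the loss on going to bromo.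

Still open, on these data alone, is where 4-chlorophenyl or unsubstituted phenyl would fall on this position, and hence whether compound 1 is an isolated high point or part of a wider trend among 4-substituted groups. Also open, as far as these compounds go, is whether the order of these four compounds would hold in a full concentration series or in other cell lines, since all of these readings come from one cell line at one concentration.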